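The compounds below may be only part of what the source reports. "The series", "measured", "known", "first", "only" and "open" are said of these compounds alone.

Of the compounds shown here, two of the same core have been measured so far. Compound 1 `NC1CCN(C(=O)c2ccc(-c3ccc4ncc(-c5ccc6cnccc6c5)n4c3)cc2)CC1` carries a 4-aminopiperidin-1-yl amide and in an assay on Sf21 cells for inhibition of MAP kinase-interacting serine/threonine-protein kinase 2 (Homo sapiens), read by luminescence and ADP-Glo, with stated times of 10 min and 40 min (a lower number here means a stronger inhibitor, a higher number a weaker inhibitor), compound 1 gives 5.2 nM. Within the data shown here, compound 2 `O=C(c1ccc(-c2ccc3ncc(-c4ccc5cnccc5c4)n3c2)cc1)N1CCC(N2CCCCC2)CC1` carries the 4-(piperidin-1-yl)piperidin-1-yl amide instead, and in this assay compound 2 gives 1.5 nM, the lowest of the two numbers; the single step seen, a 3.5-fold lower number from compound 1 to compound 2 (0.54 log units; beyond the scatter), separates them.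

Compound 3 `N[C@H]1CCCN(C(=O)c2ccc(-c3ccc4ncc(-c5ccc6cnccc6c5)n4c3)cc2)C1` is the next compound to be measured. Relative to compound 2 the change is 3-aminopiperidin-1-yl in place of 4-(piperidin-1-yl)piperidin-1-yl on a carbonyl carbon. Among the measured compounds shown here, this change largely runs the one known step backwards: an amino group on the saturated ring again replaces the piperidin-1-yl group, while the ring carbon that carries it also shifts, so compound 1 is the closest measured relative of compound 3 without being identical to it. Because a 3.5-fold lower number from compound 1 to compound 2 (0.54 log units; beyond the scatter) was modest, the reverse direction is expected to cost a similar modest amount. The estimate for compound 3 in this assay is therefore 5 nM, with a range from 2 nM to 15 nM, which means an expected step of a 3.3-fold higher number from compound 2 to compound 3 (0.52 log units; beyond the scatter).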

Compound 3, half-maximal inhibitory concentration: 2.5 nM
Compound 3: middle estimate off by 2.0-fold (0.30 log units), on the high side; the measured number falls inside the stated range.
By their numbers in this assay, from the lowest: compounds 2 and 3 (each within the scatter of the next); then compound 1.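

In this assay, the carbonyl carbon tolerates a much smaller group than the 4-(piperidin-1-yl)piperidin-1-yl group: with a 1.7-fold higher number from compound 2 to compound 3 (0.22 log units; within the scatter), the 3-aminopiperidin-1-yl group holds the number level with that of the larger group, so neither the second saturated ring nor the loss of the amino hydrogen-bond donor is needed to reach this range. The earlier step had set an amino-bearing ring apart from the larger group, but the new result shows that this holds only for the 4-aminopiperidin-1-yl group, since moving the amino group to give the 3-aminopiperidin-1-yl group brings a 2.1-fold lower number from compound 1 to compound 3 (0.32 log units; beyond the scatter), a modest step beyond the scatter. Nothing available explains why the ring carbon carrying the amino group matters here.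

Compound 3 has one defined stereocentre and its mirror-image form is absent from the compounds shown, so it remains open whether the value depends on that configuration. Also open, as far as these compounds go, is how a 3-(dimethylamino)piperidin-1-yl group or a 3-aminopyrrolidin-1-yl group would compare on the same carbonyl carbon.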